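From thiophen-2-yl to 4-methylbenzyl: an expected step

A few compounds are considered here, and "the series" means these few. Any claim that something is new, unique, unknown or untested is made for them only; others in the source may bear on it.

Measured so far:
- compound 1, `Cc1ccc(-c2nc(-c3ccc(C4=NCCN4)cc3)no2)cc1`, gives 2310 nM in an assay for inhibition of Amine oxidase [flavin-containing] A (Homo sapiens), read by fluorescence and spectrophotometry, using microsomes, with stated times of 30 min and 20 min; on this read-out higher numbers stand for weaker inhibition and lower numbers for stronger inhibition
- compound 2, `c1csc(-c2noc(-c3ccc(C4=NCCN4)cc3)n2)c1`, gives 1570 nM in this assay

Both compounds share a core and differ only in the group attached to one carbon of the five-membered ring. Compound 2 and compound 1 lie within the usual scatter of each other, so the two numbers cannot be told apart; nothing separates them beyond measurement noise.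

Compound 3, `Cc1ccc(Cc2noc(-c3ccc(C4=NCCN4)cc3)n2)cc1`, has not yet been measured. It is derived from compound 2 by one change: 4-methylbenzyl in place of thiophen-2-yl on an aromatic carbon. The sulfur-containing ring is gone, and a methylene spacer now sits between the core and the aromatic ring, which also carries a methyl group.

Within the data shown here, with no measured pair of this kind to lean on, the expected step is uncertain. The expectation is a modest weakening, with the step from compound 2 to compound 3 estimated as a 1.9-fold higher number from compound 2 to compound 3 (0.28 log units; within the scatter), although a result within the scatter would not be surprising. Compound 3 is therefore expected to give about 3000 nM in this assay, with a range from 800 nM to 12000 nM.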

Compound 3, half-maximal inhibitory concentration: 55500 nM
Compound 3: middle estimate off by 19-fold (1.27 log units), on the low side; the whole stated range lies below it.
By their numbers in this assay, from the lowest: compounds 2 and 1 (each within the scatter of the next); then compound 3.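

Putting 4-methylbenzyl in place of thiophen-2-yl on this aromatic carbon gives a 35-fold higher number from compound 2 to compound 3 (1.55 log units; beyond the scatter) in this assay, so inhibition of the enzyme falls sharply with this single change. The two earlier numbers lay within the scatter of each other and gave no hint that a change at this position could matter so much; compound 3 shows that the position is sensitive to the group it carries. The change replaces the sulfur-containing ring with a six-membered ring of carbon only and also brings in a methylene spacer and a methyl group, and no measurement here bears on which of these accounts for the loss.

As far as these compounds go, it remains open whether a plain benzyl group, a phenyl group or a 4-methylphenyl group on this same carbon would keep the inhibition of compound 2 or lose it as compound 3 does. From the compounds shown here alone, how an amine or a carboxylic acid at the end of a short chain would read at this position also remains open.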